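This account rests on a few compounds, and the source may have more. Where it says the series, first, only, none or still open, it means among the compounds named here.

- compound 1 `O=c1ccc2cc(Oc3ccc(Cl)cc3O)ccc2o1` with 96200 nM as its value
- compound 2 `Cc1cc(=O)oc2ccc(Oc3ccc(Cl)cc3O)cc12` with 35500 nM as its value

Within the data shown here, in an ADME assay on L6 cells (Rattus norvegicus) for inhibition, read by fluorescence, with a stated time of 72 h (a higher number here means a weaker inhibitor, a lower number a stronger inhibitor), compound 2 gives 35500 nM as the lowest of the two numbers so far. Compound 3 `CCc1cc(=O)oc2ccc(Oc3ccc(Cl)cc3O)cc12` carries methyl in place of hydrogen on a saturated chain carbon bound to an aromatic carbon, so methyl becomes ethyl. Among the measured compounds shown here, only one measured step bears on this: a 2.7-fold lower number from compound 1 to compound 2 (0.43 log units; beyond the scatter) for the same swap, though made on an aromatic carbon. In this assay a step no bigger than that is expected, leaning towards a lower number and possibly lost in the scatter. The expected 1.2-fold lower number from compound 2 to compound 3 (0.09 log units; within the scatter) is small. Compound 3 is estimated at 29000 nM (range 13000 nM to 65000 nM).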

Compound 3, half-maximal inhibitory concentration: 142000 nM
Estimate against measurement, compound 3: 4.9-fold (0.69 log units) below, and the stated range ends below it.
By their numbers in this assay, from the lowest: compound 2; then compounds 1 and 3 (each within the scatter of the next).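

In this assay, the lower number that methyl gave does not continue when the group grows by one carbon: methyl to ethyl gives a 4.0-fold higher number from compound 2 to compound 3 (0.60 log units; beyond the scatter) instead. Set against the hydrogen, ethyl gives a 1.5-fold higher number from compound 1 to compound 3 (0.17 log units; within the scatter) and so keeps none of the gain seen with methyl. Nothing measured here explains this reversal.

As far as these compounds go, whether a longer chain such as propyl would push the number higher still remains open. So does whether a methoxy group or an amine in this place would behave like methyl or like ethyl.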